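This account rests on a few compounds, and the source may have more. Where it says the series, first, only, none or still open, it means among the compounds named here.

Measured so far in an assay on isolated protein for inhibition of leukotriene B4 receptor 1 (Homo sapiens), tested at 10 uM; on this read-out higher numbers stand for more inhibition at the one concentration tested (going by the name of the read-out) and lower numbers for less inhibition:
compound 1 `CC(=O)c1cc(C)c(OCCCCC#N)cc1O` – 79%
compound 2 `CC(=O)c1cc(CC2CO2)c(OCCCCC#N)cc1O` – 62%
compound 3 `CC(=O)c1cc(C=O)c(OCCCCC#N)cc1O` – 6%

Compound 3 stands lowest of the three numbers in this assay: the nearest compound, compound 2, lies above it by a number 56 percentage points lower from compound 2 to compound 3 (beyond the scatter), and compound 1 by a number 73 percentage points lower from compound 1 to compound 3 (beyond the scatter), both beyond the scatter. Among the two compounds without formyl, a number 17 percentage points lower from compound 1 to compound 2 (beyond the scatter) is the only comparison, and it is modest.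

Compound 4 `C=CCc1cc(C(C)=O)c(O)cc1OCCCCC#N` is the next step from compound 3: allyl in place of formyl on an aromatic carbon. Among the measured compounds shown here, the steps that bear on it are the two in which formyl entered: a number 73 percentage points lower from compound 1 to compound 3 (beyond the scatter) and a number 56 percentage points lower from compound 2 to compound 3 (beyond the scatter), both large losses on arrival of formyl in place of a carbon substituent at this position. Compound 4 reverses that change, taking formyl out and putting a three-carbon chain in its place, so a large rise is expected in this assay, about a number 59 percentage points higher from compound 3 to compound 4 (beyond the scatter), back toward the level of compounds 1 and 2. Compound 4 is therefore estimated at 65%, with a range of 45% to 85%.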

Compound 4, a percentage reported as inhibition, at one concentration (the size of the read-out at that concentration, not a potency): 92%
The estimate for compound 4 lay 27 percentage points below the measured number; measured number outside the range, above it.
By their numbers in this assay, from the lowest: compound 3; then compound 2; then compound 1; then compound 4.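

In this assay, allyl in place of formyl on an aromatic carbon gives a number 86 percentage points higher from compound 3 to compound 4 (beyond the scatter) and so carries the number past those of compound 1 and compound 2, which shows that the low value of compound 3 is tied to formyl and does not extend to every larger group here. Vinyl in place of hydrogen on the saturated chain carbon gives a number 13 percentage points higher from compound 1 to compound 4 (beyond the scatter) while vinyl in place of oxiran-2-yl on that carbon gives a number 30 percentage points higher from compound 2 to compound 4 (beyond the scatter) and, with compound 2 lying under compound 1, this shows that the end of the chain decides the direction of the change from methyl. No measurement on hand accounts for these differences.

Still open, going by these compounds, is whether a saturated propyl chain, a longer chain, an amine or a carboxylic acid at this position would keep the number of compound 4. With one concentration tested, the order of the four compounds says nothing about their potency.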